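A few compounds are considered here, and "the series" means these few. Any claim that something is new, unique, unknown or untested is made for them only; others in the source may bear on it.

Measured so far:
Compound 1 `CC(C)(C)c1cc(NC(=O)Nc2cc(F)cc(F)c2)n(-c2ccccc2)n1`: 3 degrees C
Compound 2 `Cn1nc(C(C)(C)C)cc1NC(=O)Nc1cc(F)cc(F)c1`: 1.2 degrees C

Going by the values given here, in an assay on isolated protein for inhibition of STE20-like serine/threonine-protein kinase (Homo sapiens), read by thermal shift assay, tested at 10 uM (a higher number here means that the compound stabilises the target more against heat, a lower number that the compound stabilises the target less), compound 1 gives 3 degrees C, and compound 2 gives 1.2 degrees C. The one step measured so far, a number 1.8 degrees C lower from compound 1 to compound 2 (beyond the scatter), sets compound 2 at the lower of the two numbers, beyond the scatter. Compound 3 `Cn1nc(-c2ccccc2)cc1NC(=O)Nc1cc(F)cc(F)c1` is the next member of the series; it differs from compound 2 by phenyl in place of tert-butyl on an aromatic carbon. Among the compounds with values here, that step does not bear directly on this change, since it concerns the group on the ring nitrogen rather than the tert-butyl position, so no measured step tells how this assay responds here. The expectation therefore rests on compound 2 alone, and the step of a number 0.30 degrees C higher from compound 2 to compound 3 (within the scatter) is expected to stay within the scatter. Compound 3 is estimated at 1.5 degrees C, with a range from 0 degrees C to 3.5 degrees C.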

Compound 3, shift of the target's melting temperature: 0.8 degrees C
The estimate for compound 3 lay 0.70 degrees C above the measured number; the range from low to high includes it.
By their numbers in this assay, from the lowest: compounds 3 and 2 (each within the scatter of the next); then compound 1.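

In this assay, replacing tert-butyl with phenyl on this aromatic carbon gives a number 0.40 degrees C lower from compound 2 to compound 3 (within the scatter), so with methyl on the ring nitrogen the read-out does not separate these two groups, although phenyl adds a six-membered aromatic ring. Of the two places varied so far, only the group on the aromatic nitrogen has a step beyond the scatter, a number 1.8 degrees C lower from compound 1 to compound 2 (beyond the scatter), while the step at this carbon stays within it. Nothing available explains why the two groups read alike here.

The compounds shown leave open whether the same swap would read alike with phenyl on the ring nitrogen, as in compound 1. They also leave open how this carbon would respond to a group of another kind, such as an amine or a carboxylic acid.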